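The source may report more compounds than this note shows. Statements on the series, on what has been measured and on what is new or still open speak of the compounds shown alone.

Measured compounds:
compound 1 `N#Cc1ccc(C(=O)/C=C/c2ccncc2)cc1`, 123000 nM;
compound 2 `COc1cc(C(=O)/C=C/c2ccncc2)cc(OC)c1OC`, 7000 nM;
compound 3 `Cc1cccc(C(=O)/C=C/c2ccncc2)c1`, 39000 nM.

In a functional assay with Rattus norvegicus as the target (on this read-out lower numbers stand for stronger inhibition and higher numbers for weaker inhibition), compound 1 gives 123000 nM, the highest of the three numbers. Compound 3 gives 39000 nM, the nearest to it, and compound 2 gives 7000 nM, the furthest; both gaps from compound 1 lie beyond the scatter. Within the data shown here, no step between measured compounds that differ in one place exists here. Compound 4 `O=C(/C=C/c1ccncc1)c1ccc(C(F)(F)F)cc1` has not yet been measured. It differs from compound 1 in one place: trifluoromethyl in place of cyano on an aromatic carbon. Among the measured compounds shown here, no measured step involves a change of this kind, and the expectation rests only on compound 1 standing at the high end with 123000 nM. A modest move toward lower numbers is expected, around the edge of the scatter, a 2.5-fold lower number from compound 1 to compound 4 (0.39 log units; beyond the scatter). Compound 4 is expected to give 50000 nM, within a range from 15000 nM to 160000 nM.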

Compound 4, half-maximal inhibitory concentration: 204000 nM
Compound 4: middle estimate off by 4.1-fold (0.61 log units), on the low side, and the stated range ends below it.
By their numbers in this assay, from the lowest: compound 2; then compound 3; then compounds 1 and 4 (each within the scatter of the next).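

In this assay, trifluoromethyl in place of cyano on this aromatic carbon, para to a large group, gives a 1.7-fold higher number from compound 1 to compound 4 (0.22 log units; within the scatter), a step within the scatter. At this place the two groups cannot be told apart, although trifluoromethyl brings more heavy atoms and no hydrogen-bond acceptor, so this exchange leaves the read-out without a resolved change. No measured evidence bears on this result.

What the compounds leave open is whether an amine, a hydroxyl group or a carboxylic acid at this same place would give a number clearly apart from these two. On these data alone, whether the same exchange behaves alike on another carbon of the ring also stays open.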